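From 1-methylcyclopropyl to propyl: estimating a permeability

The source may hold more compounds than are shown below. What is called first, only, known or untested is meant among the compounds shown, and "the series" means these compounds.

Compound 1 `CC1(C[C@@H](O)C(=O)N2N=CC[C@H]2C(=O)NCc2cc(Cl)ccc2-n2cnnn2)CC1` gives 9.5 10^-6 cm/s
Compound 2 `O=C(NCc1cc(Cl)ccc1-n1cnnn1)[C@@H]1CCNN1C(=O)[C@H](O)c1ccccc1` gives 5.3 10^-6 cm/s

In an ADME assay on Caco-2 cells (Homo sapiens) for permeability, read by LC-MS, in the apical to basolateral direction, with a stated time of 60 min, at pH 6.5 (on this read-out higher numbers stand for higher permeability and lower numbers for lower permeability), compound 1 stands level with compound 2, since their two values lie within the usual scatter of each other. Compound 3 `CCCC[C@@H](O)C(=O)N1N=CC[C@H]1C(=O)NCc1cc(Cl)ccc1-n1cnnn1` has propyl in place of 1-methylcyclopropyl on a saturated chain carbon, two bonds along the chain from a carbonyl carbon and an oxygen on a saturated carbon. Among the measured compounds shown here, no measured pair shows this change, so the expectation starts from compound 1 at 9.5 10^-6 cm/s and foresees no shift beyond the scatter. The expected result is a 1.1-fold lower number from compound 1 to compound 3 (0.02 log units; within the scatter) and this stays within the scatter. For compound 3 the estimated value is 9 10^-6 cm/s with 4.5 10^-6 cm/s and 18 10^-6 cm/s as the expected ends of its range.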

Compound 3, apparent permeability: 9.8 10^-6 cm/s
Compound 3: the middle estimate sits 1.1-fold (0.04 log units) below what was measured, within the range that was stated.
By their numbers in this assay, from the lowest: compounds 2, 1 and 3 (each within the scatter of the next).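

Swapping 1-methylcyclopropyl for propyl on this saturated chain carbon removes the three-membered ring and one carbon, and in this assay this gives a 1.0-fold higher number from compound 1 to compound 3 (0.01 log units; within the scatter) on the otherwise shared core. In this one pair, the ring and the open chain therefore give values that cannot be told apart. No separate measurement bears on this result. The compounds shown leave open whether a longer chain at this position would stay within the scatter of compound 1. They also leave open how an amine or a carboxylic acid there would read.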